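The compounds below may be only part of what the source reports. "The series", "measured", "known", "first", "only" and "open" are said of these compounds alone.

Among the compounds with values here, compound 1 `c1ccc(N2CCN(CCCCOc3ccc4c(c3)CCC4)CC2)cc1` gives 75% in a functional assay on the whole organism for inhibition, with Mus musculus as the target, at a dose of 25 mg/kg by the oral route (on this read-out lower numbers stand for less inhibition and higher numbers for more inhibition at the one dose given (going by the name of the read-out)), the highest of the two numbers known. Compound 2 `Clc1cc(Cl)cc(N2CCN(CCCCOc3ccc4c(c3)CCC4)CC2)c1` gives 0% in this assay, and the change between them, 3,5-dichlorophenyl in place of phenyl on an amine nitrogen in a ring, brings a number 75 percentage points lower from compound 1 to compound 2 (beyond the scatter). Within the data shown here, compound 3 `Fc1cc2c(cc1OCCCCN1CCN(c3ccccc3)CC1)CCC2` differs from compound 1 by fluoro in place of hydrogen on an aromatic carbon, a place in the shared core that the one measured step does not touch, so that step offers no guide. For compound 3 the expected step is therefore a number 5 percentage points lower from compound 1 to compound 3 (within the scatter), within the usual scatter. Compound 3 is estimated at 70%, between 45% and 90%.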

Compound 3, a percentage reported as inhibition, in the whole organism at one dose (the size of the read-out at that dose, not a potency): 33%
Compound 3: the middle estimate sits 37 percentage points above what was measured; measured number below the stated range.
By their numbers in this assay, from the lowest: compound 2; then compound 3; then compound 1.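

In this assay the shared core proves sensitive at this aromatic carbon: fluoro in place of hydrogen gives a number 42 percentage points lower from compound 1 to compound 3 (beyond the scatter) and so, with only one heavy atom added, a step beyond the scatter. Both changes shown from compound 1, one on the phenyl and one on the core, therefore lower the number. Nothing available accounts for this drop. As far as these compounds go, whether chloro or methoxy at this carbon would behave like fluoro remains open. So does whether fluoro at another carbon of that ring would give a similar step.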